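From Allyl to Butyl: Estimating Compound 4

This account rests on a few compounds, and the source may have more. Where it says the series, first, only, none or still open, it means among the compounds named here.

Measured compounds:
- compound 1 `C=CCOC(=O)Nc1ccc([Se]C#N)cc1`: 5000 nM
- compound 2 `CCCCOC(=O)Nc1ccc([Se][Se]c2ccc(NC(=O)OCCCC)cc2)cc1`: 7200 nM
- compound 3 `Cc1ccc(OC(=O)Nc2ccc([Se][Se]c3ccc(NC(=O)Oc4ccc(C)cc4)cc3)cc2)cc1`: 3500 nM

In an ADME assay on 184B5 cells (Homo sapiens) for cytotoxicity, read by MTT assay, with a stated time of 72 h (on this read-out lower numbers stand for stronger inhibition of growth and higher numbers for weaker inhibition of growth), compound 1 gives 5000 nM. Its number lies between those of compound 2, which gives 7200 nM, and compound 3, which gives 3500 nM, but both gaps fall within the usual scatter, so the three compounds cannot be told apart on this read-out.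

Compound 4 `CCCCOC(=O)Nc1ccc([Se]C#N)cc1` has not yet been measured. It differs from compound 1 in one place: propyl in place of vinyl on a saturated chain carbon bound to an oxygen next to a carbonyl group. Cut one bond further out, this reads as allyl to butyl. Among the compounds with values here, none of the measured compounds share this change with another, so no measured step shows its size. Compounds 2 and 3, which differ from each other and from compound 1 in several places at once, give no guidance on this single change either. In this assay the step is therefore expected to be small, in no particular direction, and to stay within the scatter: the estimated step is a 1.0-fold lower number from compound 1 to compound 4 (0.02 log units; within the scatter). For compound 4 the estimated value is 4800 nM, with a range from 2000 nM to 12000 nM.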

Compound 4, concentration for 50% growth inhibition: 5300 nM
Compound 4: the middle estimate sits 1.1-fold (0.04 log units) below what was measured; the range from low to high includes it.
By their numbers in this assay, from the lowest: compounds 3, 1, 4 and 2 (each within the scatter of the next, the first and the last beyond it).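

In this assay, the change from allyloxy to butoxy gives a 1.1-fold higher number from compound 1 to compound 4 (0.03 log units; within the scatter) as the first step read at this place, on a saturated chain carbon bound to an oxygen next to a carbonyl group. For this pair, then, the double bond of the allyl group can give way to a saturated butyl chain with one more carbon, and the read-out cannot tell the two compounds apart. No separate measurement is available to explain this result.

The compounds shown leave open whether a longer chain such as octyl, an amine or a carboxylic acid at this place would leave the number just as undisturbed. A single pair also cannot say whether allyl to butyl would behave the same way on a different core.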